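Methoxymethyl in Place of Methoxy on Compound 2

A few compounds are considered here, and "the series" means these few. Any claim that something is new, unique, unknown or untested is made for them only; others in the source may bear on it.

Compound 2 `COc1cnc(N2CCC([C@H]3C[C@H]3COCc3ccc(S(C)(=O)=O)cc3F)CC2)nc1` gives 4.5 nM in a functional assay on CHO cells for agonist activity at Glucose-dependent insulinotropic receptor (Homo sapiens), read by cAMP accumulation (a higher number here means that more compound is needed for the effect, a lower number that less compound is needed), the higher of the two numbers recorded; compound 1 `CC(C)c1noc(N2CCC([C@H]3C[C@H]3COCc3ccc(S(C)(=O)=O)cc3F)CC2)n1` gives 4.2 nM. Among the measured compounds shown here, the only measured step, a 1.1-fold higher number from compound 1 to compound 2 (0.03 log units; within the scatter), exchanged the whole substituent on the ring amine and stayed within the scatter. Compound 3 `COCc1cnc(N2CCC([C@H]3C[C@H]3COCc3ccc(S(C)(=O)=O)cc3F)CC2)nc1` differs from compound 2 by methoxymethyl in place of methoxy on an aromatic carbon. For the measured compounds named here, no measured step speaks to this change directly, and the one step known showed no shift, so compound 3 is expected to move by a 1.2-fold higher number from compound 2 to compound 3 (0.09 log units; within the scatter), a step not beyond the scatter. Compound 3 is therefore estimated at 5.5 nM, within 2 nM to 15 nM.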

Compound 3, half-maximal effective concentration in the Glucose-dependent insulinotropic receptor assay: 2.1 nM
Compound 3: the middle estimate sits 2.6-fold (0.42 log units) above what was measured; the range from low to high includes it.
By their numbers in the Glucose-dependent insulinotropic receptor assay, from the lowest: compounds 3, 1 and 2 (each within the scatter of the next, the first and the last beyond it).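

Among the compounds shown here, this aromatic carbon proves sensitive to its substituent: in the Glucose-dependent insulinotropic receptor assay, methoxymethyl in place of methoxy gives a 2.1-fold lower number from compound 2 to compound 3 (0.33 log units; beyond the scatter), the first step to pass the scatter. Against the other ring-amine substituent, a 2.0-fold lower number from compound 1 to compound 3 (0.30 log units; within the scatter) does not pass it, so compound 3 cannot be ranked ahead of compound 1. The same change also comes with lower lipophilicity in a physicochemical assay for lipophilicity, read by HPLC, at pH 7 (on this read-out higher numbers stand for higher lipophilicity and lower numbers for lower lipophilicity), where compound 2 gives 4 and compound 3 gives 3.5: the measured distribution coefficient of compound 2, 4, and of compound 3, 3.5, a number 0.50 log units lower (beyond the scatter)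

One pair cannot show whether these two shifts are linked. As far as these compounds go, how a hydroxymethyl, an amine or a longer ether chain would behave on this carbon remains open.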